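Swapping a cyclohexyl for a trimethoxyphenyl on the amine

This account rests on a few compounds, and the source may have more. Where it says the series, first, only, none or still open, it means among the compounds named here.

Measured so far in a functional assay on PC-3 cells (Homo sapiens) for cytotoxicity, read by MTT assay, with a stated time of 72 h; on this read-out higher numbers stand for weaker inhibition and lower numbers for stronger inhibition:
compound 1 `COc1cc(Nc2nc(C(=N)Nc3ccccc3)cc3c(-c4ccccc4)n[nH]c23)cc(OC)c1OC` gives 5800 nM;
compound 2 `COc1ccc(Cn2nc(-c3ccccc3)c3cc(C(=N)Nc4cccc(C(F)(F)F)c4)nc(Nc4cc(OC)c(OC)c(OC)c4)c32)cc1` gives "not determined" (no result reported), so no number is reported for it;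
compound 3 `COc1ccc(Cn2nc(-c3ccccc3)c3cc(C(=N)Nc4ccccc4)nc(NC4CCCCC4)c32)cc1` gives 1100 nM.

Compound 3 therefore holds the lowest number of the two reported, and its gap to compound 1 lies beyond the usual scatter. Compound 4 `COc1ccc(Cn2nc(-c3ccccc3)c3cc(C(=N)Nc4ccccc4)nc(Nc4cc(OC)c(OC)c(OC)c4)c32)cc1` differs from compound 3 in one place: 3,4,5-trimethoxyphenyl in place of cyclohexyl on a nitrogen on an aromatic ring. Among the measured compounds shown here, no measured pair shows this exact step, so the expectation rests on compound 1, which carries the same 3,4,5-trimethoxyphenyl group and gives 5800 nM. Compound 4 is expected to land at 2500 nM, within 700 nM to 9000 nM. The estimated step of a 2.3-fold higher number from compound 3 to compound 4 (0.36 log units; beyond the scatter) points toward a weaker result, modestly beyond the scatter.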

Compound 4, half-maximal inhibitory concentration: 50000 nM
Compound 4: the middle estimate sits 20-fold (1.30 log units) below what was measured; measured number outside the range, above it.
By their numbers in this assay, from the lowest: compound 3; then compound 1; then compound 4.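

In this assay, the nitrogen-linked group matters far more than compound 1 alone could show: 3,4,5-trimethoxyphenyl in place of cyclohexyl gives a 45-fold higher number from compound 3 to compound 4 (1.66 log units; beyond the scatter). With the 3,4,5-trimethoxyphenyl kept, 4-methoxybenzyl in place of hydrogen on the aromatic nitrogen gives an 8.6-fold higher number from compound 1 to compound 4 (0.94 log units; beyond the scatter). No measurement shown explains either step.

On these data alone, whether a plain phenyl or an open-chain butyl on that nitrogen would land nearer compound 3 or compound 4 remains open. So does whether cyclohexyl would still give the lower number with hydrogen in place of 4-methoxybenzyl.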